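The source may hold more compounds than are shown below. What is called first, only, known or untested is meant among the compounds shown, and "the series" means these compounds.

Working notes on the series. The shared core carries a secondary amine, and the group on the saturated chain carbon bound to that nitrogen is varied. In an ADME assay on MDCK cells (Canis lupus familiaris) for cytotoxicity, read by microscopy, with a stated time of 48 h (a lower number here means that less compound is tolerated, a higher number that more compound is tolerated), compound 1 `CCCc1csc(CN[C@@H]2C[C@H]3C[C@@H]([C@H]2C)C3(C)C)c1` gives 12500 nM, compound 2 `C[C@H]1[C@H](NCc2ccsc2)C[C@H]2C[C@@H]1C2(C)C` gives 50000 nM, and compound 3 `CCOc1ccsc1CN[C@@H]1C[C@H]2C[C@@H]([C@H]1C)C2(C)C` gives 50000 nM. Compound 2 thus stands level with compound 3 at the digits shown, the two together giving the highest numbers of the three, while compound 1 sits a step lower that lies beyond the usual scatter.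

Compound 4 `C[C@H]1[C@H](NCc2nccs2)C[C@H]2C[C@@H]1C2(C)C` is not yet measured; it differs from compound 2 by 1,3-thiazol-2-yl in place of thiophen-3-yl on a saturated chain carbon bound to an amine nitrogen.

For the measured compounds named here, no measured pair isolates this change. The step from compound 2 to compound 4 is expected to be small, none beyond the scatter, as a 1.3-fold lower number from compound 2 to compound 4 (0.10 log units; within the scatter). Compound 2 already gives 50000 nM. Compound 3, with a different group at the same place, gives 50000 nM. For compound 4 the expected value in this assay is 40000 nM, with a range from 12500 nM to 100000 nM.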

Compound 4, minimum cytotoxic concentration: > 100000 nM
Compound 4 was reported as a limit; the forecaster's own chance of this, stated with the estimate: 15%; at least 2.5-fold (0.39 log units) between middle value and limit.
By their numbers in this assay, from the lowest: compound 1; then compounds 2 and 3 (each within the scatter of the next). At a limit, above all of these: compound 4.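

In this assay compound 4 is reported as a limit, not as a number: the limit of > 100000 nM in this assay, at which 1 of the 4 values shown sits. Placing 1,3-thiazol-2-yl in place of thiophen-3-yl on a saturated chain carbon bound to an amine nitrogen gives an at least 2.0-fold higher number from compound 2 to compound 4 (0.30 log units; that floor lies within the scatter). For the compounds shown here, this is the first sign that this place accepts a five-membered aromatic ring with 2 hetero atoms with no lower number seen, though the floor of the step lies within the scatter.

On these data alone, the true size of the step stays open. Also open, as far as these compounds go, is whether 1,3-oxazol-2-yl or pyridin-2-yl at this place would give a number or another limit.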